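Swapping Acetyl for Methylsulfonyl on the Shared Core

The source may hold more compounds than are shown below. What is called first, only, known or untested is meant among the compounds shown, and "the series" means these compounds.

Compound 1 `CC(=O)N1N=C(c2ccc(N3CCN(C)CC3)cc2)CC1c1ccc(N(C)C)cc1`: -1%
Compound 2 `Cc1ccc(C(=O)N2N=C(c3ccc(N4CCN(C)CC4)cc3)CC2c2ccc(N(C)C)cc2)cc1`: -0.7%
Compound 3 `CC(=O)N1N=C(c2ccc(-n3cncn3)cc2)CC1c1ccc(N(C)C)cc1`: 7.4%

All three were tested in a functional assay on MDA-MB-231 cells (Homo sapiens) for inhibition, read by sulforhodamine B assay, tested at 10 uM; on this read-out higher numbers stand for more inhibition at the one concentration tested (going by the name of the read-out) and lower numbers for less inhibition. Compound 3 has the highest of the three numbers, yet its gaps to compound 2 and to compound 1 both lie within the scatter, so no order can be read from them. Compound 4 `CN(C)c1ccc(C2CC(c3ccc(-n4cncn4)cc3)=NN2S(C)(=O)=O)cc1` differs from compound 3 by methylsulfonyl in place of acetyl on an amine nitrogen in a ring. Within the data shown here, no measured step makes this same change. The closest comparison is a number 0.3 percentage points higher from compound 1 to compound 2 (within the scatter), which altered the group on the carbonyl carbon without moving the number; a number 8.4 percentage points higher from compound 1 to compound 3 (within the scatter) also stayed within the scatter. Compound 4 is therefore expected to show a step of a number 2.4 percentage points lower from compound 3 to compound 4 (within the scatter). The estimate for compound 4 is 5%, with a range from -10% to 20%.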

Compound 4, a percentage reported as inhibition, at one concentration (the size of the read-out at that concentration, not a potency): 7.8%
Estimate against measurement, compound 4: 2.8 percentage points below; the range from low to high includes it.
By their numbers in this assay, from the lowest: compounds 1, 2, 3 and 4 (each within the scatter of the next).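

Moving from acetyl to methylsulfonyl on the amine nitrogen in the ring gives a number 0.4 percentage points higher from compound 3 to compound 4 (within the scatter) in this assay. This is the first change shown at this nitrogen itself, rather than on the carbonyl carbon attached to it, and at the one concentration tested the two groups cannot be told apart on this shared core. Nothing available here explains this result.

A longer chain such as butanoyl, or a phenylsulfonyl group, could still separate from these numbers at this nitrogen. On these data alone, whether methylsulfonyl behaves the same alongside 4-methylpiperazin-1-yl also stays open.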